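The source may report more compounds than this note shows. Statements on the series, on what has been measured and on what is new or still open speak of the compounds shown alone.

Compound 1 `CCCCCCCCCCCCNC[C@@H]1OC[C@H](N)[C@H]1O` gives the highest number of the three in a functional assay on B16-F10 cells (Mus musculus) for antiproliferative activity, read by MTT assay, with a stated time of 72 h (on this read-out lower numbers stand for stronger inhibition and higher numbers for weaker inhibition), where compound 1 gives 58100 nM. Its configurational partner compound 2 `CCCCCCCCCCCCNC[C@@H]1OC[C@H](N)[C@@H]1O` gives 10700 nM; the step of a 5.4-fold lower number from compound 1 to compound 2 (0.73 log units; beyond the scatter) rests on the fact that compounds 1 and 2 differ only in the configuration as drawn alone. Compound 3 `CCCCCCCCCCCCCCNC[C@@H]1OC[C@H](N)[C@@H]1O` carries the longer chain and gives 14300 nM; the step of a 1.3-fold higher number from compound 2 to compound 3 (0.13 log units; within the scatter) shows that ethyl in place of hydrogen on a saturated chain carbon, ten or more bonds along the chain from an amine nitrogen, leaves the number essentially where it stood.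

Compound 4 `CCCCCCCCCNC[C@@H]1OC[C@H](N)[C@H]1O` keeps the configuration of compound 1 and shortens the chain: hydrogen in place of propyl on a saturated chain carbon, nine bonds along the chain from an amine nitrogen. Among the compounds with values here, of the measured steps only the one from compound 2 to compound 3 bears on this change, and that step was within the scatter, so removing propyl from the chain end is expected to move the number little. A small drift upward is allowed for, but no change beyond the scatter is expected; the expected step is a 1.2-fold higher number from compound 1 to compound 4 (0.08 log units; within the scatter). Compound 4 is accordingly estimated at 70000 nM in this assay, with a range from 30000 nM to 160000 nM, and some chance that only a limit rather than a number is returned.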

Compound 4, half-maximal inhibitory concentration: > 128000 nM
Compound 4 gave a limit, no number (the forecaster's own chance of this, stated with the estimate: 20%); middle value at least 1.8-fold (0.26 log units) from the limit.
By their numbers in this assay, from the lowest: compounds 2 and 3 (each within the scatter of the next); then compound 1. At a limit, above all of these: compound 4.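

Compound 4 returns only a limit in this assay, > 128000 nM, and not a number. Even so, the change can be read as a lower bound: hydrogen in place of propyl on a saturated chain carbon, nine bonds along the chain from an amine nitrogen, gives an at least 2.2-fold higher number from compound 1 to compound 4 (0.34 log units; beyond the scatter), so removing propyl here weakens inhibition beyond the scatter. Until now the only chain change was a 1.3-fold higher number from compound 2 to compound 3 (0.13 log units; within the scatter), which left the number unresolved, so this is the first sign that the read-out responds to chain length at all, though that change lengthens the chain in the other drawn configuration and the true size of the new step stays unknown: the limit of > 128000 nM in this assay, at which 1 of the 4 values shown sits.

As far as these compounds go, whether the same shortening has the same effect in the configuration of compound 2 stays open, so the chain and configuration effects cannot yet be separated. Also open, from the compounds shown here alone, is whether a longer chain on the configuration of compound 1 would lower the number, and whether an amide in place of the chain amine would keep the activity of compound 2.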